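The compounds below may be only part of what the source reports. "The series", "measured", "known", "first", "only" and "open" are said of these compounds alone.

Measured compounds in a functional assay on MCF7 cells (Homo sapiens) for antiproliferative activity, read by sulforhodamine B assay, with a stated time of 48 h; on this read-out lower numbers stand for stronger inhibition and higher numbers for weaker inhibition:
compound 1 `COc1cccc(/C=C/C(=O)C(=Cc2ccc(F)cc2)C(=O)/C=C/c2cccc(OC)c2OC)c1OC` gives 1830 nM;
compound 2 `COc1ccc(C=C(C(=O)/C=C/c2cccc(OC)c2OC)C(=O)/C=C/c2cccc(OC)c2OC)cc1OC` gives 560 nM;
compound 3 `COc1cccc(C=C(C(=O)/C=C/c2cccc(OC)c2OC)C(=O)/C=C/c2cccc(OC)c2OC)c1OC` gives 520 nM.

Compound 1 stands highest of the three numbers in this assay, with compound 2 nearest and compound 3 furthest, both well beyond the scatter. Compound 4 `COc1ccc(C=C(C(=O)/C=C/c2cccc(OC)c2OC)C(=O)/C=C/c2cccc(OC)c2OC)cc1O` differs from compound 1 by 3-hydroxy-4-methoxyphenyl in place of 4-fluorophenyl on a double-bonded chain carbon bound to a double-bonded chain carbon. Within the data shown here, two measured steps bear on this change, since each also replaces the 4-fluorophenyl group at the same place: a 3.3-fold lower number from compound 1 to compound 2 (0.51 log units; beyond the scatter) and a 3.5-fold lower number from compound 1 to compound 3 (0.55 log units; beyond the scatter), both modest and alike in direction. The entering 3-hydroxy-4-methoxyphenyl group differs from either dimethoxyphenyl group only in its one hydrogen-bond donor, so a step of similar size and direction in this assay is expected, namely a 3.5-fold lower number from compound 1 to compound 4 (0.55 log units; beyond the scatter). Compound 4 is therefore estimated at 520 nM, within 200 nM to 1400 nM.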

Compound 4, half-maximal inhibitory concentration: 310 nM
Estimate against measurement, compound 4: 1.7-fold (0.22 log units) above; the range from low to high includes it.
By their numbers in this assay, from the lowest: compounds 4, 3 and 2 (each within the scatter of the next); then compound 1.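

In this assay, 3-hydroxy-4-methoxyphenyl in place of 4-fluorophenyl gives a 5.9-fold lower number from compound 1 to compound 4 (0.77 log units; beyond the scatter), so the lower number seen with the dimethoxyphenyl groups also holds for a group carrying a hydrogen-bond donor. Hydrogen in place of methyl gives a 1.8-fold lower number from compound 2 to compound 4 (0.26 log units; within the scatter), and the change from 2,3-dimethoxyphenyl gives a 1.7-fold lower number from compound 3 to compound 4 (0.22 log units; within the scatter); both lie within the scatter, so this assay does not separate the hydroxy group from a methoxy group here. No measurement bearing on the reason for these steps is available.

On these data alone, whether an amine or a carboxylic acid on the aromatic ring at this place would keep the lower number remains open. So does the effect of a hydroxy group on the two 2,3-dimethoxyphenyl rings of the side chains.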